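From chloro to phenyl: compound 3 to compound 4

The compounds below may be only part of what the source reports. "The series", "measured", "known", "first", "only" and "open" are said of these compounds alone.

In an ADME assay on HCT-116 cells (Homo sapiens) for cytotoxicity, read by CellTiter-Glo, with a stated time of 72 h (a lower number here means a stronger inhibitor, a higher number a weaker inhibitor), compound 3 `CC1CCN(C2CCN(S(=O)(=O)c3cccc(Cl)c3)CC2)CC1` gives > 5000 nM as a limit of the assay and not a number. Compound 1 `Cc1noc(C)c1S(=O)(=O)N1CCC(N2CCC(C)CC2)CC1` also stands at a limit with > 10000 nM as its reading. Compound 2 `COc1ccccc1-c1cccc(S(=O)(=O)N2CCC(N3CCC(C)CC3)CC2)c1` carries 2-methoxyphenyl in place of the chloro of compound 3. Compound 2 reads > 5000 nM as a limit too. The measured steps are a step that the two limits leave unreadable from compound 1 to compound 3 and a step that the two limits leave unreadable from compound 2 to compound 3 and neither gives a size.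

Compound 4 `CC1CCN(C2CCN(S(=O)(=O)c3cccc(-c4ccccc4)c3)CC2)CC1` has phenyl in place of the chloro of compound 3. The change is phenyl in place of chloro on an aromatic carbon on an aromatic carbon. Compound 2 is the closest guide and its limit of > 5000 nM suggests that no step beyond the scatter is expected in this assay for this change. The estimated step is a step that the limit leaves unreadable from compound 3 to compound 4 and it remains a rough expectation. For compound 4 the estimated value is 8000 nM with an expected range from 3000 nM to 20000 nM and the assay may well report only a limit.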

Compound 4, half-maximal inhibitory concentration: > 5000 nM
Compound 4 was reported as a limit; the forecaster's own chance of this, stated with the estimate: 80%; the middle value lies beyond the limit too.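

Compound 4 gives only a limit of this assay, as do compound 2 and compound 3, so neither step to compound 4 can be read. The compounds shown leave open how strongly any of them acts on these cells, and whether swapping these groups changes that at all.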